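The source may report more compounds than this note shows. Statements on the series, on what has been measured and on what is new or still open speak of the compounds shown alone.

In a functional assay on MCF7 cells (Homo sapiens) for antiproliferative activity, read by MTT assay, with a stated time of 48 h (on this read-out higher numbers stand for weaker inhibition and lower numbers for stronger inhibition), the three measured compounds gave the following numbers:

compound 1, `O=C(/C=C/c1cccc(NC(=O)c2ccccc2Cl)c1)c1nc2ccccc2[nH]1`: 4570 nM
compound 2, `Cc1cccc(C(=O)Nc2cccc(/C=C/C(=O)c3nc4ccccc4[nH]3)c2)c1`: 5590 nM
compound 3, `Cc1ccccc1S(=O)(=O)Nc1cccc(/C=C/C(=O)c2nc3ccccc3[nH]2)c1`: 4130 nM

Compound 3 has the lowest of the three numbers, but the others sit close to it: a 1.1-fold lower number from compound 1 to compound 3 (0.04 log units; within the scatter) and a 1.4-fold lower number from compound 2 to compound 3 (0.13 log units; within the scatter), both within the scatter, so no order among the three compounds can be read from these values. Compound 4, `Cc1cc(C)cc(S(=O)(=O)Nc2cccc(/C=C/C(=O)c3nc4ccccc4[nH]3)c2)c1`, differs from compound 3 in one place: 3,5-dimethylphenyl in place of 2-methylphenyl on a sulfonyl sulfur. The measured steps all vary this same end of the molecule. The step of a 1.2-fold higher number from compound 1 to compound 2 (0.09 log units; within the scatter) exchanges one substituted phenyl for another on a carbonyl carbon, and the two steps into compound 3 replace a carbonyl by a sulfonyl together with a change of the phenyl. Each of these stayed within the scatter. No measured pair changes the phenyl on the sulfonyl sulfur on its own, so the step to compound 4 has no direct precedent, but the nearby changes give no reason to expect a move beyond the scatter in either direction. Compound 4 is therefore expected to give about 4200 nM in this assay, with a range from 2000 nM to 9000 nM. For compound 4 this estimate means an expected step of a 1.0-fold higher number from compound 3 to compound 4 (0.01 log units; within the scatter).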

Compound 4, half-maximal inhibitory concentration: 4570 nM
For compound 4 the middle estimate is 1.1-fold (0.04 log units) below the measured one, and the stated range covers the measured number.
By their numbers in this assay, from the lowest: compounds 3, 1, 4 and 2 (each within the scatter of the next).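

In this assay, the step on the sulfonyl sulfur, with 3,5-dimethylphenyl in place of 2-methylphenyl and the sulfonamide nitrogen left as it is, gives a 1.1-fold higher number from compound 3 to compound 4 (0.04 log units; within the scatter). This is the first pair among these compounds that changes only the phenyl group on that sulfur, whereas the earlier steps into compound 3 changed the carbonyl to a sulfonyl together with the phenyl, so the read-out does not separate these two methyl-bearing phenyl groups at this place. No measurement at hand bears on why the two groups read alike.

Every group shown at this end of the molecule is a substituted phenyl carrying methyl or chloro, so it remains open whether an amine, a carboxylic acid or a longer alkyl chain on the sulfonyl sulfur would give a step beyond the scatter. The shared core is also the same in all four compounds, so these numbers say nothing about how changes there, such as a methyl group on the amide or sulfonamide nitrogen, would read.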